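The source may hold more compounds than are shown below. What is called first, only, known or untested is meant among the compounds shown, and "the series" means these compounds.

Measured compounds in an assay on HEK293 cells for inhibition of acid ceramidase (Homo sapiens), with a stated time of 10 min; on this read-out higher numbers stand for weaker inhibition and lower numbers for stronger inhibition:
- compound 1 `O=C(NCCCCc1ccccc1)n1c(=O)oc2ccccc21`: 64 nM
- compound 2 `O=C(NCCCCc1ccccc1)n1c(=O)oc2ccc(Br)cc21`: 22 nM
- compound 3 `Cc1ccc2c(c1)oc(=O)n2C(=O)NCCCCc1ccccc1`: 66 nM

Compound 1 stands second highest of the three numbers. Its nearest neighbour is compound 3, and the methyl-on-core step reads a 1.0-fold higher number from compound 1 to compound 3 (0.01 log units; within the scatter), so these two sit within the scatter of one another. The furthest is compound 2, and the bromo-on-core step reads a 2.9-fold lower number from compound 1 to compound 2 (0.46 log units; beyond the scatter), a modest step beyond the scatter.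

Compound 4 `O=C(NCCCCCc1ccccc1)n1c(=O)oc2ccccc21` differs from compound 1 by benzyl in place of phenyl on a saturated chain carbon, four bonds along the chain from an amide-type nitrogen. Both measured steps change a substituent on the aromatic core and leave the chain untouched; neither bears on a lengthening of the chain by one carbon. Within the data shown here, no measured pair shows what such a change does in this assay, so there is no basis for expecting a step in either direction beyond the scatter, and the uncertainty is correspondingly wide.

The step expected from this change is no change at the digits printed from compound 1 to compound 4 (within the scatter), essentially flat, anchored on compound 1 at 64 nM. Compound 4 is therefore estimated at 64 nM, with a range of 20 nM to 200 nM.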

Compound 4, half-maximal inhibitory concentration: 54 nM
The estimate for compound 4 lay 1.2-fold (0.07 log units) above the measured number; measured number inside the range.
By their numbers in this assay, from the lowest: compound 2; then compounds 4, 1 and 3 (each within the scatter of the next).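

In this assay, the chain gets its first reading: benzyl in place of phenyl on a saturated chain carbon, four bonds along the chain from an amide-type nitrogen, gives a 1.2-fold lower number from compound 1 to compound 4 (0.07 log units; within the scatter) and so leaves the read-out flat at this place. The earlier steps shown here changed only substituents on the aromatic core, so the chain had no reading until now, and this change is accepted with no shift that can be told from the scatter. Among these compounds, the bromo step, a 2.9-fold lower number from compound 1 to compound 2 (0.46 log units; beyond the scatter), therefore remains the only step beyond the scatter, and no measurement on hand bears on why the chain step is flat.

As far as these compounds go, the reading covers a single change in chain length, so whether phenethyl at this place or a still longer chain stays as flat remains open, as does a shorter chain and whether the flat reading would hold with the bromo of compound 2 on the core. Also open, from the compounds shown here alone, is what an amine or a carboxylic acid carried on the chain would do.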